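The source may report more compounds than this note shows. Statements on the series, on what has been measured and on what is new or still open speak of the compounds shown alone.

Measured so far in a functional assay on cells (Cancer cell lines, Homo sapiens) for cytotoxicity, with a stated time of 48 h; on this read-out lower numbers stand for stronger inhibition of growth and higher numbers for weaker inhibition of growth:

Compound 1 `COc1ccc(CN2C(=O)/C(=C\c3cc(OC)c(OC)c(OC)c3)c3ccccc32)cc1` gives 2300 nM
Compound 2 `COc1cc(/C=C2/C(=O)N(C)c3ccc(O)cc32)cc(OC)c1OC` gives 3200 nM
Compound 3 `COc1ccc2c(c1)/C(=C\c1cc(OC)c(OC)c(OC)c1)C(=O)N2C` gives 2700 nM

These three values lie within the usual scatter of one another, so compound 1 stands level with compound 2 and compound 3. Compound 4 `COc1cc(/C=C2\C(=O)N(Cc3ccc(Cl)cc3)c3ccccc32)cc(OC)c1OC` differs from compound 1 in one place, where the 4-methoxybenzyl group becomes a 4-chlorobenzyl group: chloro in place of methoxy on an aromatic carbon is the whole change. Within the data shown here, no measured step makes this swap, and no measured compound carries a chloro group. Among the measured compounds shown here, the only step available is a different change, a 1.2-fold lower number from compound 2 to compound 3 (0.07 log units; within the scatter), so it bears on this question only loosely. Compound 2 and compound 3 also lack the 4-methoxybenzyl group of compound 1, yet their values stay within the scatter of its value. With a step as small as a 1.2-fold lower number from compound 2 to compound 3 (0.07 log units; within the scatter) to go on, no step beyond the scatter is expected in this assay and no direction can be called. The expected step is a 1.0-fold higher number from compound 1 to compound 4 (0.02 log units; within the scatter), which is an estimate only. For compound 4 the estimated value is 2400 nM, with an expected range from 1000 nM to 5500 nM, and the measurement is still to come.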

Compound 4, concentration for 50% growth inhibition: 2400 nM
The estimate for compound 4 equals the measured number at the digits printed, and the stated range covers the measured number.
By their numbers in this assay, from the lowest: compounds 1, 4, 3 and 2 (each within the scatter of the next).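

In this assay, chloro in place of methoxy at this spot on the ring gives a 1.0-fold higher number from compound 1 to compound 4 (0.02 log units; within the scatter), so compound 1 and compound 4 stand level. Among these compounds, until now, the 4-methoxybenzyl group had been seen only on compound 1, and this pair shows that 4-chlorobenzyl reads the same, even though its ring substituent has a single chlorine atom where methoxy has a carbon and an oxygen. Nothing measured here explains why the two compounds read alike.

Compound 1 and compound 4 do not show whether an amine or a carboxylic acid at this same ring position would also leave the number within the scatter. They also leave open what a longer chain in place of the benzyl group would do.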